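The source may hold more compounds than are shown below. What is called first, only, known or untested is meant among the compounds shown, and "the series" means these compounds.

Measured compounds:
- Compound 1, `COc1ccc(/C=C/C=C/C(=O)c2ccccc2O)cc1`: 1810 nM
- Compound 2, `O=C(/C=C(O)/C=C/c1ccc([N+](=O)[O-])cc1)c1ccccc1O`: 2670 nM

Both compounds were tested in an in vitro assay on cells for inhibition of Amine oxidase [flavin-containing] B (Homo sapiens), read by Amplex Red, with a stated time of 15 min; on this read-out lower numbers stand for stronger inhibition and higher numbers for weaker inhibition. Compound 1 gives 1810 nM, and compound 2 gives 2670 nM. On the numbers shown, compound 2 stands alongside compound 1: the gap between the two values lies within the usual scatter of repeated measurements, so the two cannot be told apart with any confidence. Both share the same core, a hydroxyphenyl ketone joined through a short unsaturated chain to a second aromatic ring, and they differ only in the group carried by that second ring.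

Compound 3, `Cc1ccc(/C=C/C(O)=C/C(=O)c2ccccc2O)cc1`, has not yet been measured. Compared with compound 2, the change is methyl in place of nitro on an aromatic carbon. Within the data shown here, no step between two measured compounds of this set is available to show what such a swap on this ring does. Given that compound 1 and compound 2 already sit within the scatter of each other despite different groups at this place, no step beyond the scatter is expected in this assay. The expected step from compound 2 to compound 3 is a 1.3-fold lower number from compound 2 to compound 3 (0.10 log units; within the scatter). Compound 3 is estimated at 2100 nM, with a range from 900 nM to 4800 nM.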

Compound 3, half-maximal inhibitory concentration: 3770 nM
Estimate against measurement, compound 3: 1.8-fold (0.25 log units) below, within the range that was stated.
By their numbers in this assay, from the lowest: compounds 1, 2 and 3 (each within the scatter of the next, the first and the last beyond it).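

Among these compounds, the comparison of compound 2 with compound 3 gives the first direct reading at this position, on an aromatic carbon para to a large group: exchanging nitro for methyl in this assay gives a 1.4-fold higher number from compound 2 to compound 3 (0.15 log units; within the scatter). Nitro carries hydrogen-bond acceptors and methyl carries none, and the two groups also differ in heavy-atom count, yet this large change in the group does not separate the two compounds on this read-out. The data offer no measured basis for explaining this outcome.

From the compounds shown here alone, this single step covers only nitro and methyl at this carbon, so it remains open whether an amine, a carboxylic acid, a chlorine atom or a longer chain there would move the number beyond the scatter in this assay. Among the compounds shown here, also open is whether methyl in place of nitro would give a similar step on a different core, since only this one matched pair is available.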